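Replacing Carboxy with 2-Carboxyethenyl on Compound 2

The compounds below may be only part of what the source reports. "The series", "measured", "known", "first", "only" and "open" are said of these compounds alone.

Compound 1 `CC1CCC(=NNc2ccccc2)c2ncc(C(=O)O)c(=O)n21` and compound 2 `C[C@@H]1CC/C(=N\Nc2ccccc2)c2ncc(C(=O)O)c(=O)n21` share the same atoms and bonds and differ only in how their stereo elements are drawn. In a functional assay on the whole organism with Rattus norvegicus as the target (a lower number here means that less compound is needed, a higher number that more compound is needed for the effect), compound 1 gives 0.6 umol/kg, while compound 2 gives 54.8 umol/kg, the highest of the three numbers measured. For the measured compounds named here, the step of a 91-fold higher number from compound 1 to compound 2 (1.96 log units; beyond the scatter) is the only measured step, and its size may be connected with the fact that one of compounds 1 and 2 is drawn with a defined configuration and the other without, at the place where they differ. Compound 3 `Cc1cccc(/N=C/C2=C3NC=C(C(=O)O)C(=O)N3C(C)CC2)c1` gives 0.8 umol/kg. Compound 4 `C[C@@H]1CC/C(=N\Nc2ccccc2)c2ncc(/C=C/C(=O)O)c(=O)n21` differs from compound 2 by 2-carboxyethenyl in place of carboxy on an aromatic carbon. Going by the values given here, no measured step involves this change, so no shift beyond the scatter is assumed, though the uncertainty is wide. Compound 4 is therefore expected to give about 60 umol/kg, within 10 umol/kg to 350 umol/kg. The expected step is a 1.1-fold higher number from compound 2 to compound 4 (0.04 log units; within the scatter).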

Compound 4, dose for 50% inhibition: > 100 umol/kg
Compound 4: only a limit was reported; the forecaster's own chance of this, stated with the estimate: 20%; middle value at least 1.6-fold (0.22 log units) away from the limit.
By their numbers in this assay, from the lowest: compounds 1 and 3 (each within the scatter of the next); then compound 2. At a limit, above all of these: compound 4.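

For the compounds shown here, replacing carboxy with 2-carboxyethenyl on this aromatic carbon gives the first measured change at this position: an at least 1.8-fold higher number from compound 2 to compound 4 (0.26 log units; that floor lies within the scatter). In this assay, compound 4 has only a limit and not a number: the limit of > 100 umol/kg in this assay, at which 1 of the 4 values shown sits. From the compounds shown here alone, the longer group therefore gave no lower number here, but the floor of the step stays within the scatter, so the size of any real rise remains unknown.

Going by these compounds, it remains open how an ester or an amide would read at this aromatic carbon. On these data alone, whether 2-carboxyethenyl would read the same on compound 1 also remains open.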